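A few compounds are considered here, and "the series" means these few. Any claim that something is new, unique, unknown or untested is made for them only; others in the source may bear on it.

Of the compounds shown here, two share a core and have been measured in a functional assay on CHO cells for agonist activity at Alpha-1A adrenergic receptor (Homo sapiens), read by FLIPR and calcium flux; a lower number here means a smaller maximal response, a higher number a larger maximal response. Compound 1 `c1ccc(-c2cccc3c2CCC3c2ncc[nH]2)nc1` carries a pyridin-2-yl on an aromatic carbon of that core, and in this assay compound 1 gives 53%. Compound 2 `c1ccc2c(c1)CCC2c1ncc[nH]1` has a hydrogen in that place, and in this assay compound 2 gives 54%, the higher of the two numbers, though the step of a number 1 percentage points higher from compound 1 to compound 2 (within the scatter) is within the scatter. Compound 3 `Cn1cc(-c2cccc3c2CCC3c2ncc[nH]2)cn1` differs from compound 2 by 1-methyl-1H-pyrazol-4-yl in place of hydrogen on an aromatic carbon. Among the compounds with values here, the only step that bears on this change is the one from compound 1 to compound 2, in which removing an aromatic ring from the same place moved the response by a number 1 percentage points higher from compound 1 to compound 2 (within the scatter), within the scatter. Adding a different aromatic ring at that place is therefore expected to give a step of a number 1 percentage points lower from compound 2 to compound 3 (within the scatter), not beyond the scatter. Compound 3 is estimated at 53%, between 38% and 68%.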

Compound 3, largest response reached (Emax), in percent of the reference or control that the assay uses: 12%
Compound 3: middle estimate off by 41 percentage points, on the high side; the measured number lies below the stated range.
By their numbers in this assay, from the lowest: compound 3; then compounds 1 and 2 (each within the scatter of the next).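

In this assay, this aromatic carbon does not treat every aromatic ring alike: 1-methyl-1H-pyrazol-4-yl in place of hydrogen gives a number 42 percentage points lower from compound 2 to compound 3 (beyond the scatter), whereas pyridin-2-yl at the same place left compound 1 within the scatter of compound 2. Exchanging one ring for the other gives a number 41 percentage points lower from compound 1 to compound 3 (beyond the scatter), so the response depends on which ring is attached, not simply on whether a ring is present. Nothing available here accounts for this difference between the two rings.

As far as these compounds go, it remains open whether the drop follows the five-membered ring itself or its methyl group, which the unmethylated 1H-pyrazol-4-yl ring could help to separate. From the compounds shown here alone, how a non-ring group at this carbon, such as an amine or a carboxylic acid, would change the maximal response also remains open.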